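Replacing naphthalen-2-yl with 3-chlorophenyl in compound 2

The source may report more compounds than this note shows. Statements on the series, on what has been measured and on what is new or still open speak of the compounds shown alone.

Compound 1 `Cc1cc(Nc2ccc(C(=O)/C=C/c3ccc(F)cc3)cc2)n2nc(SCc3nc4ccccc4[nH]3)nc2n1` gives 85 nM 
Compound 2 `Cc1cc(Nc2ccc(C(=O)/C=C/c3ccc4ccccc4c3)cc2)n2nc(SCc3nc4ccccc4[nH]3)nc2n1` gives 5 nM 
Compound 3 `Cc1cc(Nc2ccc(C(=O)/C=C/c3ccc4ccccc4c3)cc2)n2nc(SCC(=O)c3ccccc3)nc2n1` gives 190 nM 

All three numbers come from a functional assay on SW-620 cells (Homo sapiens) for cytotoxicity, read by MTT assay, with stated times of 4 h and 72 h, tested at 2 uM (on this read-out lower numbers stand for stronger inhibition and higher numbers for weaker inhibition), and a lower number means a stronger effect on the cells. Among the measured compounds shown here, compound 2 holds the lowest number of the three, and its steps to both others lie beyond the scatter, so it is the most potent compound so far.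

Compound 4 `Cc1cc(Nc2ccc(C(=O)/C=C/c3cccc(Cl)c3)cc2)n2nc(SCc3nc4ccccc4[nH]3)nc2n1` has not been measured yet. It differs from compound 2 in one place: 3-chlorophenyl in place of naphthalen-2-yl on a double-bonded chain carbon bound to a double-bonded chain carbon with 3-chlorophenyl in place of naphthalen-2-yl on a double-bonded chain carbon bound to a double-bonded chain carbon.

The best guide comes from that same place, where the measured change is a 17-fold lower number from compound 1 to compound 2 (1.23 log units; beyond the scatter) with naphthalen-2-yl in place of 4-fluorophenyl. Compound 4 also gives up naphthalen-2-yl for a substituted phenyl, so a large rise in the number is expected. The other step, a 38-fold higher number from compound 2 to compound 3 (1.58 log units; beyond the scatter) is also large, but it lies elsewhere in the molecule and says little here. For the measured compounds named here, no measured compound carries 3-chlorophenyl, so the size remains uncertain.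

The step expected in this assay is an 8.0-fold higher number from compound 2 to compound 4 (0.90 log units; beyond the scatter) by this estimate. Compound 4 is estimated at 40 nM (expected range 10 nM to 160 nM).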

Compound 4, half-maximal inhibitory concentration: 400 nM
Compound 4: middle estimate off by 10-fold (1.00 log units), on the low side, and the stated range ends below it.
By their numbers in this assay, from the lowest: compound 2; then compound 1; then compound 3; then compound 4.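

Placed on a double-bonded chain carbon bound to a double-bonded chain carbon, 3-chlorophenyl gives in this assay an 80-fold higher number from compound 2 to compound 4 (1.90 log units; beyond the scatter) and so shows that the advantage of naphthalen-2-yl over a single substituted ring can be larger than compound 1 alone suggested. Among the compounds shown here, until now only one single-ring group had been seen here, and the new comparison shows that the choice among such rings also counts: there is a 4.7-fold higher number from compound 1 to compound 4 (0.67 log units; beyond the scatter) and this modest step still lies beyond the scatter. The two-ring naphthalen-2-yl group therefore gives the lowest number of the three compounds that differ only in this place, but these data give no explanation for the differences, either for the change of ring or for the change of halogen.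

4-Fluorophenyl and 3-chlorophenyl differ both in the halogen and in where it sits, so the compounds shown cannot say which of the two matters, and 4-chlorophenyl or 3-fluorophenyl would separate them. Plain phenyl would show what the bare ring gives without any halogen, and naphthalen-1-yl would test whether two fused rings are enough or whether their arrangement matters as well.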